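Changing the aryl group on an amidrazone series

This account rests on a few compounds, and the source may have more. Where it says the series, first, only, none or still open, it means among the compounds named here.

Measured so far, in an ADME assay on L6 cells (Rattus norvegicus) for cytotoxicity, read by resazurin assay, with a stated time of 72 h; a lower number here means a stronger inhibitor, a higher number a weaker inhibitor:
- compound 1 `N/C(CC(O)c1cccc2ccccc12)=N\N=C\c1ccc(F)cc1F` gives 4200 nM
- compound 2 `Cc1ccc(/C=N/N=C(\N)CC(O)c2cccc3ccccc23)cc1` gives 6800 nM

Compound 2 stands beside compound 1 only: the step of a 1.6-fold higher number from compound 1 to compound 2 (0.21 log units; within the scatter) shows the two numbers lie within the scatter of each other, so neither can be called the stronger.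

Compound 3 `N/C(CC(O)c1cccc2ccccc12)=N\N=C\c1ccc(Cl)c(Cl)c1` differs from compound 2 by 3,4-dichlorophenyl in place of 4-methylphenyl on a carbon with a double bond to nitrogen. Among the measured compounds shown here, the one measured step that bears on an aryl change at this carbon, a 1.6-fold higher number from compound 1 to compound 2 (0.21 log units; within the scatter), stayed within the scatter, so the expected step of a 1.2-fold lower number from compound 2 to compound 3 (0.09 log units; within the scatter) is likewise expected to stay within the scatter, with no direction implied. Compound 3 is therefore estimated at 5500 nM, with a range from 2000 nM to 15000 nM.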

Compound 3, half-maximal inhibitory concentration: 16000 nM
For compound 3 the middle estimate is 2.9-fold (0.46 log units) below the measured one, outside the stated range (above it).
By their numbers in this assay, from the lowest: compounds 1 and 2 (each within the scatter of the next); then compound 3.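

At this position the aryl group can matter after all: in this assay the 3,4-dichlorophenyl group gives a 2.4-fold higher number from compound 2 to compound 3 (0.37 log units; beyond the scatter) and also a 3.8-fold higher number from compound 1 to compound 3 (0.58 log units; beyond the scatter) for the change from 2,4-difluorophenyl. Both steps are modest, but they pass the scatter, which makes compound 3 the weakest inhibitor of the three. Nothing shown explains this shift. Open still is whether the result follows from having two chlorine atoms or from chlorine itself, since no aryl group here carries a single chlorine. As far as these compounds go, how a methoxy group, an amine or a carboxylic acid on this ring would read also remains unknown.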